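Two limits, and a change at the amide nitrogen

This account rests on a few compounds, and the source may have more. Where it says the series, first, only, none or still open, it means among the compounds named here.

Compound 1 `O=C(/C=C/CCCCCCc1ccccc1)Nc1ccccc1` gives > 100000 nM as a limit
Compound 2 `O=C(/C=C/CCCCCCc1ccccc1)N[C@H]1CC[C@H](O)CC1` gives > 100000 nM as a limit

Compound 2 stands at > 100000 nM in a functional assay on PANC-1 cells (Homo sapiens) for cytotoxicity, read by WST assay, with a stated time of 24 h (on this read-out lower numbers stand for stronger inhibition and higher numbers for weaker inhibition), and this is a limit of the assay, not a number. Among the measured compounds shown here, the series so far shows the limit of > 100000 nM in this assay, at which 2 of the 2 values shown sit, and nothing finer. Compound 3 `O=C(/C=C/CCCCCCc1ccccc1)N1CCC(O)CC1` carries 4-hydroxypiperidin-1-yl in place of (4-hydroxycyclohexyl)amino on a carbonyl carbon. For the measured compounds named here, the only measured step that bears on this change is a step that the two limits leave unreadable from compound 1 to compound 2 and it offers no size to carry over. No shift beyond the usual scatter is therefore expected in this assay and no direction is favoured. The expected move is a number no higher from compound 2 to compound 3 (the limit leaves the size open) as an estimate only. Compound 3 is estimated at about 100000 nM with an expected range from 50000 nM to 200000 nM and a limit of the assay is expected again.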

Compound 3, half-maximal inhibitory concentration: > 100000 nM
Compound 3: no number, only a limit; the forecaster's own chance of this, stated with the estimate: 80%; the middle value lies on the limit itself.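

In this assay compound 3 gives > 100000 nM, which is a limit of the assay and not a number. Among the compounds shown here, no step among compound 1, compound 2 and compound 3 can be read. The compounds shown leave open how any change at the amide nitrogen would alter the read-out, as all share one limit: the limit of > 100000 nM in this assay, at which 3 of the 3 values shown sit.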